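Trimming a side chain from isopropyl to ethyl

The source may report more compounds than this note shows. Statements on the series, on what has been measured and on what is new or still open speak of the compounds shown alone.

Compound 1 `COCCc1cc(C(=O)C(=O)Nc2ccc(OC)nc2)c2ccccn12`: 36 nM
Compound 2 `COc1ccc(NC(=O)C(=O)c2cc(C(C)C)n3ccccc23)cn1`: 160 nM

In a functional assay on FaDu cells (Homo sapiens) for cytotoxicity, read by MTT assay, with a stated time of 72 h (on this read-out lower numbers stand for higher toxicity in this test and higher numbers for lower toxicity in this test), compound 2 has the higher of the two numbers at 160 nM, which makes it the less toxic of the pair. Compound 3 `CCc1cc(C(=O)C(=O)Nc2ccc(OC)nc2)c2ccccn12` keeps the shared core but shortens isopropyl to ethyl: hydrogen in place of methyl on a saturated chain carbon bound to an aromatic carbon and a saturated chain carbon. Put simply, this is hydrogen in place of methyl on a saturated chain carbon bound to an aromatic carbon and a saturated chain carbon. For the measured compounds named here, only one measured step bears on this change: a 4.4-fold higher number from compound 1 to compound 2 (0.65 log units; beyond the scatter). That step, isopropyl in place of 2-methoxyethyl on an aromatic carbon, is modest but beyond the scatter. With this single step as a guide, a smaller move toward lower numbers is expected, with real uncertainty about its direction. The estimated change is a 2.0-fold lower number from compound 2 to compound 3 (0.30 log units; within the scatter). Compound 3 is expected at about 80 nM, with an estimated range of 30 nM to 200 nM.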

Compound 3, concentration lethal to 50% of the cells: 110 nM
Compound 3: the middle estimate sits 1.4-fold (0.14 log units) below what was measured; low and high end bracket the measured number.
By their numbers in this assay, from the lowest: compound 1; then compounds 3 and 2 (each within the scatter of the next).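

Trimming one methyl from isopropyl to ethyl makes no difference that can be told from the scatter in this assay (a 1.5-fold lower number from compound 2 to compound 3 (0.16 log units; within the scatter)), so at this position these two plain carbon chains cannot be separated. Replacing the methoxy of the 2-methoxyethyl chain with hydrogen is a clearer change (a 3.1-fold higher number from compound 1 to compound 3 (0.49 log units; beyond the scatter)), so among these three compounds, compound 1 alone stands apart from the others, with the lowest number. No measured evidence here explains why the chain with the methoxy goes with that lower number.

Still open, going by these compounds, is whether the oxygen itself matters, which a 2-hydroxyethyl chain or a longer chain ending in methoxy would help to test. A 2-aminoethyl chain at the same place would show whether a nitrogen at the chain end behaves like the methoxy.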